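Lengthening a methyl on the nitrogen to allyl

The source may report more compounds than this note shows. Statements on the series, on what has been measured and on what is new or still open speak of the compounds shown alone.

Measured compounds:
compound 1 `C=C(C)C[N+](C)(C)c1cccc(OC)c1`: > 3000 nM; compound 2 `COc1ccccc1[N+](C)(C)Cc1ccccc1`: > 3000 nM; compound 3 `COc1ccc(C(=O)COc2ccc([N+](C)(C)C)cc2)cc1OC`: 9800 nM.

All three were tested in a functional assay with Cavia porcellus as the target; on this read-out higher numbers stand for weaker inhibition and lower numbers for stronger inhibition. The value for compound 1 is a limit of the assay and not a number. The value for compound 2 is likewise a limit. For the measured compounds named here, compound 3 is therefore the only compound with a measured number on this read-out, and that number is weak; the two other results sit at the limit of > 3000 nM in this assay, at which 2 of the 3 values shown sit. Going by the values given here, because no two measured compounds differ in a single place, no step between them can be read off.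

Compound 4 `C=CC[N+](C)(C)c1ccc(OCC(=O)c2ccc(OC)c(OC)c2)cc1` has not yet been measured in this assay. It differs from compound 3 by vinyl in place of hydrogen on a saturated chain carbon bound to a nitrogen on an aromatic ring, so the methyl bound to the nitrogen on the aromatic ring becomes an allyl, while the rest of the molecule is unchanged. With no measured step of this kind among the compounds shown, the expectation rests on the weak number of compound 3 alone. A step from compound 3 to compound 4 of roughly a 1.0-fold higher number from compound 3 to compound 4 (0.01 log units; within the scatter) is expected, within the usual scatter and in no clear direction. Compound 4 is thus estimated at 10000 nM, in a range from 3000 nM to 30000 nM.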

Compound 4, half-maximal inhibitory concentration: 500 nM
Compound 4: middle estimate off by 20-fold (1.30 log units), on the high side; the whole stated range lies above it.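

In this assay, turning one methyl on the nitrogen on the aromatic ring into an allyl, with the rest of the molecule unchanged, gives a 20-fold lower number from compound 3 to compound 4 (1.29 log units; beyond the scatter). For the compounds shown here, this is the first step that can be read, and since a lower number means stronger inhibition, it shows that this position is sensitive to the group it carries and that a small change there can matter far more than the usual scatter. Compounds 1 and 2 give no second step for comparison, as each differs from compound 4 in more than one place and their results are limits of the assay rather than numbers: the limit of > 3000 nM in this assay, at which 2 of the 4 values shown sit.

From the compounds shown here alone, what remains open is whether the gain depends on the double bond of the allyl group or simply on a longer chain, a question that a saturated propyl group at the same place would help to answer, and a propargyl group, with a triple bond, would extend. Going by these compounds, it also remains open whether the same change from methyl to allyl would have a similar effect on a different core, and no measured result here gives a reason for the gain.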